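The source may report more compounds than this note shows. Statements on the series, on what has been measured and on what is new or still open speak of the compounds shown alone.

Compounds measured so far:
compound 1, `Cc1cccc(NC(=O)N[C@H](C)c2ccccc2)c1`, 47%
compound 2, `Cc1cccc(NC(=O)N[C@@H](C)c2ccccc2)c1`, 100%
compound 3, `CCc1ccccc1NC(=O)N[C@H](C)c1ccccc1`, 92%

Compound 2 stands at the top of the three numbers in an ADME assay on the whole organism with Oryza sativa as the target, tested at 10 uM; a lower number here means a stronger effect, a higher number a weaker effect of the compound at the concentration tested. Its nearest neighbour is compound 3, which gives 92%, a gap that lies within the scatter, so the two cannot be ordered. Compound 1 lies farthest away with 47%; the step of a number 53 percentage points higher from compound 1 to compound 2 (beyond the scatter) is large and rests on (the fact that compounds 1 and 2 differ only in the configuration as drawn).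

Compound 4, `CC(C)c1cccc(NC(=O)N[C@@H](C)c2ccccc2)c1`, has not yet been measured. It differs from compound 2 in one place: isopropyl in place of methyl on an aromatic carbon.

Within the data shown here, no measured step changes a group on the ring, so none bears directly on this change. Among the measured compounds shown here, the only measured step concerns configuration, and compound 4 keeps the configuration of compound 2. For this reason a step of no more than the scatter is expected in this assay, with a slight lean downward since compound 2 already gives the largest number. The expected step from compound 2 to compound 4 is a number 8 percentage points lower from compound 2 to compound 4 (within the scatter). Compound 4 is estimated at 92%, between 68% and 100%.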

Compound 4, a percentage reported as activity, at one concentration (the size of the read-out at that concentration, not a potency): 86%
For compound 4 the middle estimate is 6 percentage points above the measured one; measured number inside the range.
By their numbers in this assay, from the lowest: compound 1; then compounds 4, 3 and 2 (each within the scatter of the next, the first and the last beyond it).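

Among these compounds, the change to isopropyl in place of methyl on an aromatic carbon is the only one at a group on the ring, and it gives a number 14 percentage points lower from compound 2 to compound 4 (beyond the scatter). The position meta to a large group therefore responds in this assay to the size of the group it carries, a modest step that keeps the configuration of compound 2 unchanged. The information at hand on these compounds concerns configuration alone and offers no explanation for this step.

As far as these compounds go, it remains open whether a tert-butyl group, a methoxy group or an amine at this place would continue the same direction. From the compounds shown here alone, it is also open whether isopropyl would produce a step of similar size on the core of compound 1, which carries the stereocentre drawn R.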